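From oxiran-2-yl to 2-chloro-1-hydroxyethyl on a shared core

This account rests on a few compounds, and the source may have more. Where it says the series, first, only, none or still open, it means among the compounds named here.

For the measured compounds named here, in a functional assay on MCF7 cells (Homo sapiens) for cytotoxicity, read by MTT assay (a higher number here means a weaker inhibitor, a lower number a stronger inhibitor), compound 1 (`COc1ccc(C(=O)/C=C/c2ccc(OCC3CO3)cc2)cc1`) gives 10900 nM, the higher of the two numbers measured so far. Going by the values given here, the only other measured compound, compound 2 (`O=C(/C=C/c1ccc(OCC2CO2)cc1)c1ccc(OCC2CO2)cc1`), gives 3870 nM. Compound 1 is therefore the weaker of the pair. It differs from compound 2 by a hydrogen where compound 2 carries an oxiran-2-yl, on a saturated chain carbon bound to an oxygen on an aromatic ring.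

Compound 3 (`COc1ccc(C(=O)/C=C/c2ccc(OCC(O)CCl)cc2)cc1`) keeps the core of compound 1 but exchanges one group: 2-chloro-1-hydroxyethyl in place of oxiran-2-yl on a saturated chain carbon bound to an oxygen on an aromatic ring. Here an oxiran-2-yl leaves, and 2-chloro-1-hydroxyethyl, which has no ring, enters in its place. Among the compounds with values here, the only measured step that bears on this is a 2.8-fold lower number from compound 1 to compound 2 (0.45 log units; beyond the scatter), a modest change that adds an oxiran-2-yl rather than exchanging one. It offers a rough size and no firm direction, so no step beyond the scatter is expected in this assay. The estimated change is a 1.1-fold higher number from compound 1 to compound 3 (0.04 log units; within the scatter). Compound 3 is expected at 12000 nM, with an estimated range of 4500 nM to 30000 nM.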

Compound 3, half-maximal inhibitory concentration: 29200 nM
The estimate for compound 3 lay 2.4-fold (0.39 log units) below the measured number; low and high end bracket the measured number.
By their numbers in this assay, from the lowest: compound 2; then compound 1; then compound 3.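

The exchange at this position, on a saturated chain carbon bound to an oxygen on an aromatic ring, is not neutral: in this assay it gives a 2.7-fold higher number from compound 1 to compound 3 (0.43 log units; beyond the scatter), a step beyond the usual scatter. For the compounds shown here, until now, the only step available was the addition of an oxiran-2-yl, a 2.8-fold lower number from compound 1 to compound 2 (0.45 log units; beyond the scatter), so these three compounds now show a lower number when an oxiran-2-yl is gained and a higher number when one is lost, with no compound here going against that. Nothing measured here explains why the number rises with this exchange.

The compounds shown leave open whether the higher number goes with the loss of the three-membered ring or with the arrival of the chlorine or the hydroxyl, as the exchange brings these changes together. A 2,3-dihydroxypropyl group, which has the hydroxyl but no chlorine, or a plain propyl chain, which has neither, would help to separate these possibilities, and an amine in place of the chlorine would test how much that atom matters.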